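The source may hold more compounds than are shown below. What is called first, only, known or untested is meant among the compounds shown, and "the series" means these compounds.

Of the compounds shown here, three built on one shared core have so far been tested in a functional assay on MCF7 cells (Homo sapiens) for cytotoxicity, read by sulforhodamine B assay, with a stated time of 48 h; a higher number here means a weaker inhibitor, a lower number a stronger inhibitor. Compound 1 `C=CCn1c(-c2ccc(Cl)cc2)cc(-c2ccc(Cl)cc2)c(C#N)c1=O` gives 19 ug/mL in this assay. Compound 3 `N#Cc1c(-c2ccc(Cl)cc2)cc(-c2ccc(Cl)cc2)n(C(=O)c2ccccc2)c1=O` gives 2.6 ug/mL, while compound 2 `N#CCn1c(-c2ccc(Cl)cc2)cc(-c2ccc(Cl)cc2)c(C#N)c1=O` is reported as "not active" (no number reported). Among the two numbers in hand, compound 1 holds the higher one. Its nearest measured neighbour differs only on the aromatic nitrogen, and that step, a 7.3-fold lower number from compound 1 to compound 3 (0.86 log units; beyond the scatter), is a modest one beyond the scatter. Compound 4 `N#Cc1c(-c2ccc(Cl)cc2)cc(-c2ccc(Cl)cc2)[nH]c1=O` has not yet been measured in this assay. It differs from compound 1 in one place: hydrogen in place of allyl on an aromatic nitrogen. For the measured compounds named here, the only step that touches the same position is a 7.3-fold lower number from compound 1 to compound 3 (0.86 log units; beyond the scatter), which lowered the number by a modest amount, while compound 2 shows that another group on the same nitrogen can remove activity altogether. Going by the values given here, no measured compound carries a hydrogen at this position, so the direction of the change is uncertain. Compound 4 is expected to give 30 ug/mL in this assay, with a range from 8 ug/mL to 100 ug/mL. This estimate amounts to an expected step of a 1.6-fold higher number from compound 1 to compound 4 (0.20 log units; within the scatter).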

Compound 4, half-maximal inhibitory concentration: "not active" (no number reported)
Nothing numeric was reported for compound 4, and the estimate cannot be compared.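

For the compounds shown here, compound 4 is reported in this assay without a number, so no step from compound 1 or compound 3 to compound 4 can be read. No evidence at hand bears on this result. The compounds shown leave open what hydrogen on the aromatic nitrogen does to the number, compared with allyl or benzoyl.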